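Swapping an ethoxy for two chlorines: expected cytotoxicity

The source may report more compounds than this note shows. Statements on the series, on what has been measured and on what is new or still open speak of the compounds shown alone.

Of the compounds shown here, three sharing one core have been tested in an ADME assay on HEK293 cells (Homo sapiens) for cytotoxicity, read by CellTiter-Glo and resazurin assay, with a stated time of 72 h; on this read-out higher numbers stand for an effect only at larger amounts of compound and lower numbers for an effect already at smaller amounts. Compound 1 `CC(=O)Nc1cccc(-c2ccc(C(=O)N(Cc3cccc(OCCCCCC(=O)O)c3)C(C)C)cc2)c1` gives a limit of > 26000 nM, not a number. Compound 2 `CC(C)Oc1cccc(-c2ccc(C(=O)N(Cc3cccc(OCCCCCC(=O)O)c3)C(C)C)cc2)c1` likewise gives only a limit, > 26000 nM. Compound 3 `CCOc1cccc(-c2ccc(C(=O)N(Cc3cccc(OCCCCCC(=O)O)c3)C(C)C)cc2)c1` also reaches only a limit, > 20800 nM. All three values are limits, so the steps between them cannot be read: a step that the two limits leave unreadable from compound 1 to compound 2, a step that the two limits leave unreadable from compound 1 to compound 3 and a step that the two limits leave unreadable from compound 2 to compound 3 all stay hidden, as the limit of > 20800 nM in this assay, at which 1 of the 3 values shown sits, and the limit of > 26000 nM in this assay, at which 2 of the 3 values shown sit, show. Within the data shown here, compound 3 therefore stands level with its neighbours as far as the numbers go, with no compound showing an effect within the tested range.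

Compound 4 `CC(C)N(Cc1cccc(OCCCCCC(=O)O)c1)C(=O)c1ccc(-c2ccc(Cl)c(Cl)c2)cc1` has not yet been measured in this assay. It differs from compound 3 by 3,4-dichlorophenyl in place of 3-ethoxyphenyl on an aromatic carbon. Among the measured compounds shown here, none of the measured steps bears directly on this change, and the measured steps give no size to go by. For the measured compounds named here, the only guide is that all three measured compounds sit at limits, so no step beyond the scatter is expected; the step that the limit leaves unreadable from compound 3 to compound 4 is an estimate without a measured anchor. Compound 4 is therefore expected to give 30000 nM, within 10000 nM and 100000 nM, most likely again as a limit.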

Compound 4, half-maximal effective concentration: > 26000 nM
Compound 4 gave a limit, no number; the forecaster's own chance of this, stated with the estimate: 70%; the middle value lies beyond the limit too.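

In this assay compound 4 gives > 26000 nM, which is a limit and not a number. Among these compounds, compound 1, compound 2 and compound 3 also reach only limits, so no step from any of them to compound 4 can be read. The compounds shown leave open at what concentration any of them would show an effect.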